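The source may report more compounds than this note shows. Statements on the series, on what has been measured and on what is new or still open speak of the compounds shown alone.

Compound 1 `COCC(=O)OCCc1c(-c2ccccc2Cl)c2cc(Cl)ccc2[nH]c1=O` is one of three close relatives that share a core and differ only in the group attached to a carbonyl carbon. In an ADME assay on HepG2 2.2.15 cells (Homo sapiens) for cytotoxicity (a lower number here means that less compound is tolerated, a higher number that more compound is tolerated), compound 1 gives 74000 nM. Compound 2 `O=C(OCCc1c(-c2ccccc2Cl)c2cc(Cl)ccc2[nH]c1=O)C1CCCCC1` carries a cyclohexyl in that position and gives 38000 nM, while compound 3 `CC(=O)N1CCC(C(=O)OCCc2c(-c3ccccc3Cl)c3cc(Cl)ccc3[nH]c2=O)CC1` carries a 1-acetylpiperidin-4-yl and gives 82000 nM. The number for compound 1 is the second highest of the three, yet its separation from either companion lies within the scatter of repeated measurements: the step of a 1.9-fold lower number from compound 1 to compound 2 (0.29 log units; within the scatter) and the step of a 1.1-fold higher number from compound 1 to compound 3 (0.04 log units; within the scatter). Among the compounds with values here, only the step of a 2.2-fold higher number from compound 2 to compound 3 (0.33 log units; beyond the scatter) is large enough to count as a real, if modest, difference.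

Compound 4 `O=C(/C=C/c1ccccc1)OCCc1c(-c2ccccc2Cl)c2cc(Cl)ccc2[nH]c1=O` is the next member of the series. Compared with compound 1 the change is 2-phenylethenyl in place of methoxymethyl on a carbonyl carbon. The closest guide is the step of a 1.9-fold lower number from compound 1 to compound 2 (0.29 log units; within the scatter), in which methoxymethyl was likewise replaced, and it stayed within the scatter, as did a 1.1-fold higher number from compound 1 to compound 3 (0.04 log units; within the scatter). On that basis the step expected is a 1.5-fold lower number from compound 1 to compound 4 (0.17 log units; within the scatter), small and leaning toward a lower number. Compound 4 is accordingly estimated at 50000 nM, with a range from 20000 nM to 120000 nM.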

Compound 4, half-maximal cytotoxic concentration: 230000 nM
Estimate against measurement, compound 4: 4.6-fold (0.66 log units) below; measured number above the stated range.
By their numbers in this assay, from the lowest: compounds 2, 1 and 3 (each within the scatter of the next, the first and the last beyond it); then compound 4.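

The group on this carbonyl carbon can shift the number by more than the first three compounds suggested: with 2-phenylethenyl there are steps beyond the scatter against all three, a 3.1-fold higher number from compound 1 to compound 4 (0.49 log units; beyond the scatter) and a 2.8-fold higher number from compound 3 to compound 4 (0.45 log units; beyond the scatter) and a 6.1-fold higher number from compound 2 to compound 4 (0.78 log units; beyond the scatter). Compound 4 therefore stands highest of the four, meaning that the most compound is tolerated in this assay. A six-membered ring made only of carbon does not by itself go with a high number, as compound 2 also carries one in its cyclohexyl, yet it gives the largest step to compound 4, and no measurement at hand explains why 2-phenylethenyl behaves this way.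

The compounds shown do not separate the aromatic ring from the double bond outside it, and a phenyl or a 2-phenylethyl on the same carbonyl carbon would pull those two features apart. Going by these compounds, how an amine or a carboxylic acid at this position would read also remains open.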